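Cytotoxicity notes on a piperidine-carboxamide series

The source may report more compounds than this note shows. Statements on the series, on what has been measured and on what is new or still open speak of the compounds shown alone.

Of the compounds shown here, two of the shared core have been measured in an ADME assay on PC-3 cells (Homo sapiens) for cytotoxicity, read by WST assay, tested at 100 uM; a lower number here means less inhibition, a higher number more inhibition at the concentration tested (going by the name of the read-out). Compound 1 `O=C(Nc1cccc(Oc2ccccc2)c1)C1CCCN(C(=O)c2cc(C(F)(F)F)cc(C(F)(F)F)c2)C1` gives 1%. Compound 2 `O=C(c1ccccc1)c1cccc(NC(=O)C2CCCN(C(=O)c3cc(C(F)(F)F)cc(C(F)(F)F)c3)C2)c1` gives 0%. Going by the values given here, the only measured step, a number 1 percentage points lower from compound 1 to compound 2 (within the scatter), is within the scatter. Compound 2 stands lowest of the two numbers, and its nearest neighbour is compound 1, the gap between them within the scatter, so no order can be claimed between them.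

Compound 3 `O=C(Nc1cccc(S(=O)(=O)N2CCCC2)c1)C1CCCN(C(=O)c2cc(C(F)(F)F)cc(C(F)(F)F)c2)C1` is the next case. Relative to compound 2 it differs thus: (pyrrolidin-1-yl)sulfonyl in place of benzoyl on an aromatic carbon. Among the compounds with values here, the one measured step bears only loosely on this change, since it swaps a different group at the same place on the aromatic carbon meta to a large group; still, that step was within the scatter. A step of no size beyond the scatter is therefore expected, a number 2 percentage points higher from compound 2 to compound 3 (within the scatter). For compound 3 the estimate in this assay is 2%, with a range from -6% to 12%.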

Compound 3, a percentage reported as inhibition, at one concentration (the size of the read-out at that concentration, not a potency): 0%
Compound 3: the middle estimate sits 2 percentage points above what was measured; low and high end bracket the measured number.
By their numbers in this assay, from the lowest: compounds 2, 3 and 1 (each within the scatter of the next).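

At this position, on an aromatic carbon meta to a large group, (pyrrolidin-1-yl)sulfonyl in place of benzoyl gives no change at the digits printed from compound 2 to compound 3 (within the scatter) in this assay, and in place of phenoxy it gives a number 1 percentage points lower from compound 1 to compound 3 (within the scatter). A group with a five-membered non-aromatic ring and no six-membered aromatic ring thus joins the two groups that carry such an aromatic ring, with all three compounds within the scatter of one another, so the number in this assay is so far level across three different groups at this place. No supporting measurement bears on this result. From the compounds shown here alone, whether an amine or a carboxylic acid on this aromatic carbon would move the number beyond the scatter stays open. Equally open, going by these compounds, is whether a change elsewhere on the shared core would do so.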